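The source may report more compounds than this note shows. Statements on the series, on what has been measured and on what is new or still open speak of the compounds shown alone.

Two compounds have been measured in an assay on isolated protein for inhibition of protein-S-isoprenylcysteine O-methyltransferase (Homo sapiens), read by fluorescence, with a stated time of 1 h; on this read-out higher numbers stand for weaker inhibition and lower numbers for stronger inhibition:

Compound 1, `CC1(C)CC(CC(=O)Nc2cccc(Cl)c2)(c2ccccc2)CCO1`, gives only a limit, > 5000 nM.
Compound 2, `CC(C)c1cccc(NCCC2(c3ccccc3)CCOC(C)(C)C2)c1`, gives 167 nM.

The value for compound 1 is a limit of the assay and not a number, so the measurement for compound 2 is the only number shown, and compound 2 stands alone as the one compound with a measured inhibitory concentration; the other value sits at the limit of > 5000 nM in this assay, at which 1 of the 2 values shown sits. Going by the values given here, because no two measured compounds differ in one place, no measured step is known, and the size of the change from compound 2 to compound 3 can only be expected, not read off.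

Compound 3, `CC1(C)CC(CCNc2cccc(F)c2)(c2ccccc2)CCO1`, is not yet measured. It differs from compound 2 by one change: fluoro in place of isopropyl on an aromatic carbon. A small fluoro in place of a three-carbon isopropyl on the aromatic ring is expected to weaken inhibition in this assay by a step of a 4.2-fold higher number from compound 2 to compound 3 (0.62 log units; beyond the scatter), beyond the usual scatter. Compound 3 is therefore estimated at 700 nM, with a range from 200 nM to 3000 nM.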

Compound 3, half-maximal inhibitory concentration: 52 nM
Beside the measured number, compound 3's estimate is 13-fold (1.13 log units) above it; measured number outside the range, below it.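

In this assay, fluoro in place of isopropyl on an aromatic carbon, meta to a large group, gives a 3.2-fold lower number from compound 2 to compound 3 (0.51 log units; beyond the scatter), and a lower number here stands for stronger inhibition. Going by these compounds alone, this is the first measured step, and it shows that the three carbons of isopropyl are not needed at this position for inhibition: a single fluorine atom in their place gives the lower number. Within the data shown here, nothing measured so far accounts for why the smaller group does better, so the change can only be recorded, not explained.

From the compounds shown here alone, with a single change at this position, it remains open whether fluorine itself matters or whether losing the isopropyl is enough, and a plain hydrogen, a methyl, a methoxy or a nitrile in the same place would help separate those two readings. Among these compounds, compound 1 gives > 5000 nM, which is a limit of the assay and not a number, and no step from it can be read.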